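The source may hold more compounds than are shown below. What is called first, only, known or untested is meant among the compounds shown, and "the series" means these compounds.

Three compounds share a core in which a seven-carbon chain ending in phenyl is attached through a carbonyl. Compound 1 `COc1ccccc1-c1cnc(C(=O)CCCCCCc2ccccc2)o1` gives 400 nM in an assay (Rattus norvegicus) for inhibition of Fatty-acid amide hydrolase 1 (Homo sapiens); on this read-out lower numbers stand for stronger inhibition and higher numbers for weaker inhibition. Compound 2 `O=C(CCCCCCc1ccccc1)c1ncc(-c2cccc(C(=O)C(F)(F)F)c2)o1` gives 16 nM in the same assay, and compound 3 `N#Cc1cccc(-c2cnc(C(=O)CCCCCCc3ccccc3)o2)c1` gives 15 nM. Compound 3 cannot be separated from compound 2, since the step of a 1.1-fold lower number from compound 2 to compound 3 (0.03 log units; within the scatter) lies within the scatter, while the step of a 27-fold lower number from compound 1 to compound 3 (1.43 log units; beyond the scatter) sets it well apart from compound 1.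

Compound 4 `NC(=O)c1ccc(-c2cnc(C(=O)CCCCCCc3ccccc3)o2)cc1` carries the change (4-carbamoylphenyl in place of 3-cyanophenyl on an aromatic carbon). For the measured compounds named here, no measured step exchanges a group at this position of the phenyl ring, so the direct bearing is limited. The step of a 27-fold lower number from compound 1 to compound 3 (1.43 log units; beyond the scatter) shows that the aryl substituent can move the number by a large amount, whereas the step of a 1.1-fold lower number from compound 2 to compound 3 (0.03 log units; within the scatter) shows that two different groups at the 3-position can leave it unchanged. Going by the values given here, a carbamoyl at the 4-position has no precedent here, so a modest weakening is expected, of the size a 2.7-fold higher number from compound 3 to compound 4 (0.43 log units; beyond the scatter). Compound 4 is therefore estimated at 40 nM, within a range from 12 nM to 150 nM.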

Compound 4, inhibition constant: 10 nM
Compound 4: middle estimate off by 4.0-fold (0.60 log units), on the high side; the measured number lies below the stated range.
By their numbers in this assay, from the lowest: compounds 4, 3 and 2 (each within the scatter of the next); then compound 1.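

In this assay 4-carbamoylphenyl and 3-cyanophenyl cannot be told apart on the aromatic carbon next to the ring oxygen: the step of a 1.5-fold lower number from compound 3 to compound 4 (0.18 log units; within the scatter) stays within the scatter, although the entering group carries a hydrogen-bond donor and the leaving group carries none. The step of a 40-fold lower number from compound 1 to compound 4 (1.60 log units; beyond the scatter) sets 4-carbamoylphenyl, like 3-cyanophenyl, well apart from 2-methoxyphenyl, so this carbon tolerates a change of both group and ring placement without the number rising. Nothing measured here accounts for how close these two numbers lie.

From the compounds shown here alone, whether the number follows the carbamoyl group or its place on the phenyl ring stays open, as does what a carboxylic acid or an amine would give on the same carbon. Going by these compounds, it is also open whether the methoxy group itself or its place on the ring sets compound 1 apart.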